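This account rests on a few compounds, and the source may have more. Where it says the series, first, only, none or still open, it means among the compounds named here.

Measured in an ADME assay on HEK293 cells (Homo sapiens) for cytotoxicity, read by fluorescence and resazurin assay, with a stated time of 24 h; on this read-out lower numbers stand for higher toxicity in this test and higher numbers for lower toxicity in this test
- compound 1 `COc1ccc(-c2nnc(SC3=CS(=O)(=O)c4ccccc43)o2)cc1`: 2000 nM
- compound 2 `COc1cccc(-c2nnc(SC3=CS(=O)(=O)c4ccccc43)o2)c1`: 3000 nM

Compound 2 lies within the scatter of compound 1, so the two numbers do not separate. Next is compound 3 `Cc1ccc(-c2nnc(SC3=CS(=O)(=O)c4ccccc43)o2)cc1` with 4-methylphenyl in place of 3-methoxyphenyl on an aromatic carbon. Among the measured compounds shown here, the one measured step bearing on this is a 1.5-fold higher number from compound 1 to compound 2 (0.18 log units; within the scatter) and it stays within the scatter. For the measured compounds named here, no measured compound carries 4-methylphenyl, so no step beyond the scatter is expected in this assay. The estimated change is a 1.2-fold lower number from compound 2 to compound 3 (0.08 log units; within the scatter). Compound 3 is expected at 2500 nM with an estimated range of 1000 nM to 6000 nM.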

Compound 3, half-maximal cytotoxic concentration: 3000 nM
For compound 3 the middle estimate is 1.2-fold (0.08 log units) below the measured one; measured number inside the range.
By their numbers in this assay, from the lowest: compounds 1, 2 and 3 (each within the scatter of the next).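

In this assay, 4-methylphenyl in place of 3-methoxyphenyl gives no change at the digits printed from compound 2 to compound 3 (within the scatter), and methyl in place of methoxy gives a 1.5-fold higher number from compound 1 to compound 3 (0.18 log units; within the scatter). Both steps stay within the scatter, so at this position a group with no hydrogen-bond acceptor does not separate from the two methoxy-bearing groups. No other data on the series bear on this result.

As far as these compounds go, whether an amine or a carboxylic acid in place of the methyl of compound 3 would give a step beyond the scatter remains open. From the compounds shown here alone, the effect of any change to the shared core is also open.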